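Putting an Aromatic Tail Back onto a Bile Acid Receptor Ligand

The source may hold more compounds than are shown below. What is called first, only, known or untested is meant among the compounds shown, and "the series" means these compounds.

The three measured compounds share one core and differ at a single aromatic carbon. Compound 1 `COC(=O)/C=C/c1cccc(N(Cc2ccc(-c3ccc(F)c(F)c3)cc2)C(=O)C2CCCCC2)c1` and compound 2 `COC(=O)/C=C/c1cccc(N(Cc2ccc(-c3ccc(F)c(Cl)c3)cc2)C(=O)C2CCCCC2)c1` each carry a further six-membered aromatic ring of carbon only at that carbon. In an assay on isolated protein with Bile acid receptor (Homo sapiens) as the target (a lower number here means that less compound is needed, a higher number that more compound is needed for the effect), compound 1 gives 72 nM. Compound 2 gives 66 nM in this assay, and the step of a 1.1-fold lower number from compound 1 to compound 2 (0.04 log units; within the scatter) stays inside the usual scatter. Compound 3 `COC(=O)/C=C/c1cccc(N(Cc2ccccc2)C(=O)C2CCCCC2)c1` carries only hydrogen at that carbon. For compound 3 this assay reports only a limit, > 1000 nM, and not a number. That value sits at the limit of > 1000 nM in this assay, at which 1 of the 3 values shown sits. Compound 3 therefore stands at the weak end of the measured set. The steps of an at least 13-fold higher number from compound 1 to compound 3 (1.14 log units; beyond the scatter) and an at least 15-fold higher number from compound 2 to compound 3 (1.18 log units; beyond the scatter) show how much the extra ring matters. Compound 4 `COC(=O)/C=C/c1cccc(N(Cc2ccc(-c3ccc(SC)cc3)cc2)C(=O)C2CCCCC2)c1` arises from compound 3 through the change (4-(methylsulfanyl)phenyl in place of hydrogen on an aromatic carbon). This restores a six-membered aromatic ring of carbon only at the same carbon, so the two large steps bear directly on it, now run the other way. A large fall in the number is expected, an at least 12-fold lower number from compound 3 to compound 4 (1.09 log units; beyond the scatter). Compound 4 is estimated at 80 nM, within 30 nM to 300 nM.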

Compound 4, half-maximal effective concentration: 69 nM
For compound 4 the middle estimate is 1.2-fold (0.06 log units) above the measured one; measured number inside the range.
By their numbers in this assay, from the lowest: compounds 2, 4 and 1 (each within the scatter of the next). At a limit, above all of these: compound 3.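

Compound 3 is known only through a limit of this assay, not a number: the limit of > 1000 nM in this assay, at which 1 of the 4 values shown sits. Placing 4-(methylsulfanyl)phenyl on this aromatic carbon still gives a large step, an at least 14-fold lower number from compound 3 to compound 4 (1.16 log units; beyond the scatter), so the return of the ring does not depend on fluoro or chloro being on it. The sulfur-bearing tail also stands level with both halogen-bearing tails, with a 1.0-fold higher number from compound 2 to compound 4 (0.02 log units; within the scatter) and a 1.0-fold lower number from compound 1 to compound 4 (0.02 log units; within the scatter), so across these three tails the choice of substituent on the added ring shifts the number only within the scatter.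

On these data alone, it remains open whether an unsubstituted phenyl at this carbon would reach the same level. As far as these compounds go, it is equally open whether a ring carrying an amine or a carboxylic acid would keep the number there, or whether a ring containing nitrogen could replace the all-carbon one.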